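Aryl variation at the saturated ring carbon: compound 4

The compounds below may be only part of what the source reports. "The series", "measured", "known", "first", "only" and "open" are said of these compounds alone.

Measured so far:
compound 1 `N#CC1=C(N)OC(c2c[nH]c3ccccc23)=C(C#N)C1c1ccccc1F` — "not active" (no number reported)
compound 2 `N#CC1=C(N)OC(c2c[nH]c3ccccc23)=C(C#N)C1c1ccc(Br)cc1` — 14.2%
compound 3 `Cc1ccccc1C1C(C#N)=C(N)OC(c2c[nH]c3ccccc23)=C1C#N` — 10.4%

In a functional assay, tested at 50 ug/mL (a lower number here means a weaker effect, a higher number a stronger effect of the compound at the concentration tested), compound 2 gives the highest of the two reported numbers. For the measured compounds named here, the only step between numbered compounds, a number 3.8 percentage points lower from compound 2 to compound 3 (within the scatter), lies within the scatter, so compound 2 and compound 3 are not separated by this assay. Compound 1 is reported without a number.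

Compound 4 `N#CC1=C(N)OC(c2c[nH]c3ccccc23)=C(C#N)C1c1ccccc1Cl` differs from compound 2 by 2-chlorophenyl in place of 4-bromophenyl on a saturated ring carbon. The measured step that bears on this change is a number 3.8 percentage points lower from compound 2 to compound 3 (within the scatter), which also replaces the 4-bromophenyl of compound 2 with a 2-substituted phenyl on the same saturated ring carbon and produces no movement beyond the scatter. Compound 1, the remaining comparison, offers no number. On this basis the step of a number 4.2 percentage points lower from compound 2 to compound 4 (within the scatter) is expected to stay small, with no movement beyond the scatter, though the outcome for compound 1 leaves room for a weaker result. Compound 4 is therefore estimated at 10%, within a range from 2% to 18%.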

Compound 4, a percentage reported as activity, at one concentration (the size of the read-out at that concentration, not a potency): 8.5%
Beside the measured number, compound 4's estimate is 1.5 percentage points above it, within the range that was stated.
By their numbers in this assay, from the lowest: compounds 4, 3 and 2 (each within the scatter of the next).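

In this assay, a number 5.7 percentage points lower from compound 2 to compound 4 (within the scatter), so 2-chlorophenyl and 4-bromophenyl on the saturated ring carbon are not separated. Chloro in place of methyl on the aromatic carbon gives a number 1.9 percentage points lower from compound 3 to compound 4 (within the scatter), so 2-chlorophenyl and 2-methylphenyl are not separated either, and all three numbered compounds now lie within the scatter of one another. No measurement is available that would account for these small steps.

From the compounds shown here alone, compound 1 gives "not active" (no number reported), so steps to it cannot be read, and whether 2-fluorophenyl truly differs from 2-chlorophenyl stays open. Also open, going by these compounds, is whether a phenyl carrying an amine or a carboxylic acid, or a longer chain in place of the phenyl at this carbon, would move this assay beyond the scatter.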